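Replacing a Propyl Chain with a Fluorophenylsulfonamide

The source may report more compounds than this note shows. Statements on the series, on what has been measured and on what is new or still open speak of the compounds shown alone.

Compound 2 `CCCCc1cn(C[C@H](O)[C@H]2OC(=O)C(OCc3ccccc3)=C2OCc2ccccc2)nn1`: 73200 nM
Compound 1 `CCCCCc1ccc(-c2cn(C/C=C3\OC(=O)C(OCc4ccccc4)=C3OCc3ccccc3)nn2)cc1`: > 100000 nM

Among the compounds with values here, in a functional assay on CFPAC-1 cells (Homo sapiens) for antiproliferative activity, read by MTT assay, with a stated time of 72 h (on this read-out lower numbers stand for stronger inhibition and higher numbers for weaker inhibition), compound 2 gives 73200 nM, the only plain number among the two measured compounds. For compound 1 the result in this assay is a limit of the assay, > 100000 nM. Compound 3 `O=C1O[C@H]([C@@H](O)Cn2cc(CNS(=O)(=O)c3ccc(F)cc3)nn2)C(OCc2ccccc2)=C1OCc1ccccc1` arises from compound 2 by ((4-fluorophenyl)sulfonyl)amino in place of propyl on a saturated chain carbon bound to an aromatic carbon. Within the data shown here, no measured step between compounds is available to guide this change, so the expectation rests on compound 2 alone: a step of a 1.5-fold lower number from compound 2 to compound 3 (0.17 log units; within the scatter) is expected, of modest size and possibly within the scatter. Compound 3 is estimated at 50000 nM in this assay, with a range from 10000 nM to 150000 nM.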

Compound 3, half-maximal inhibitory concentration: 34700 nM
Compound 3: middle estimate off by 1.4-fold (0.16 log units), on the high side; measured number inside the range.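

In this assay, within the data shown here, the first step that can be read at this position is modest: a 2.1-fold lower number from compound 2 to compound 3 (0.32 log units; beyond the scatter). The saturated chain carbon bound to an aromatic carbon can therefore carry ((4-fluorophenyl)sulfonyl)amino, with its extra aromatic ring, in place of propyl without the number rising. Nothing measured here explains this step.

The compounds shown leave open which part of the new group matters: the fluorine, the sulfonyl or the ring. A simple amine or a longer alkyl chain at this place would help separate these.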